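Chloroacetamide series: alpha-branching of the warhead on the shared core

This account rests on a few compounds, and the source may have more. Where it says the series, first, only, none or still open, it means among the compounds named here.

Measured so far:
compound 1 `O=C(O)/C=C/C(=O)Nc1cccc(-c2nc3ccccc3s2)c1` gives > 25000 nM
compound 2 `O=C(CCl)Nc1cccc(-c2nc3ccccc3s2)c1` gives 8500 nM

In an ADME assay on BJ cells (Homo sapiens) for inhibition, with a stated time of 72 h (on this read-out lower numbers stand for an effect already at smaller amounts and higher numbers for an effect only at larger amounts of compound), compound 1 reaches only a limit of the assay, > 25000 nM. Going by the values given here, compound 2 `O=C(CCl)Nc1cccc(-c2nc3ccccc3s2)c1` is the only compound of the pair with a number, 8500 nM. Among the compounds with values here, the one comparison available, an at least 2.9-fold lower number from compound 1 to compound 2 (0.46 log units; beyond the scatter), ends at the limit of > 25000 nM in this assay, at which 1 of the 2 values shown sits, and so gives only a floor for its size. Compound 3 `CC(C)(CCl)C(=O)Nc1cccc(-c2nc3ccccc3s2)c1` carries the change (1-(chloromethyl)-1-methylethyl in place of chloromethyl on a carbonyl carbon). Within the data shown here, no measured step bears on this change: the step from compound 1 to compound 2 exchanged the whole group on the carbonyl carbon, whereas here the chloromethyl is kept and two methyls are added on the carbon next to the carbonyl. Among the measured compounds shown here, with no direct precedent, a small shift toward higher numbers beyond the scatter is expected for compound 3, a 1.8-fold higher number from compound 2 to compound 3 (0.25 log units; within the scatter). Compound 3 is therefore estimated at 15000 nM in this assay, within 5000 nM to 40000 nM.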

Compound 3, half-maximal effective concentration: > 25000 nM
Compound 3 ended at the assay's limit; the forecaster's own chance of this, stated with the estimate: 30%; middle value at least 1.6-fold (0.22 log units) from the limit.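

In this assay, the change to 1-(chloromethyl)-1-methylethyl on the carbonyl carbon gives an at least 2.9-fold higher number from compound 2 to compound 3 (0.46 log units; beyond the scatter), so the number moves upward even though the chlorine stays in the group. The earlier step exchanged the whole group on that carbon, whereas this one shows that a chlorine-bearing group there does not by itself hold the number seen for compound 2. The value of compound 3 is a limit of the assay, so the size of this step is only a floor, and the step from compound 1 to compound 3 cannot be read: the limit of > 25000 nM in this assay, at which 2 of the 3 values shown sit.

Open, going by these compounds, is whether 1-chloroethyl on the same carbonyl carbon would stay close to compound 2. Also open, on these data alone, is whether a tert-butyl group there, without chlorine, would behave like compound 3.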